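Sulfamide to urea on the aminomethyl tetralin sulfone series

A few compounds are considered here, and "the series" means these few. Any claim that something is new, unique, unknown or untested is made for them only; others in the source may bear on it.

Of the compounds shown here, two have been measured in an assay on isolated protein for displacement of a labelled ligand from 5-hydroxytryptamine receptor 6 (Homo sapiens); on this read-out higher numbers stand for weaker inhibition and lower numbers for stronger inhibition. Compound 1 `CS(=O)(=O)c1cccc(S(=O)(=O)c2ccc3c(c2)CCC[C@H]3CN)c1` gives 3.98 nM. Compound 2 `CNS(=O)(=O)NC[C@@H]1CCCc2cc(S(=O)(=O)c3cccc(F)c3)ccc21` gives 1 nM, the lowest of the two numbers; the gap to compound 1 is beyond the usual scatter, so compound 2 stands as the stronger inhibitor of the pair. Within the data shown here, no single-point step between measured compounds is available, so there is no measured precedent for how the group on the amine nitrogen sets the potency.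

Compound 3 `NC(=O)NC[C@@H]1CCCc2cc(S(=O)(=O)c3cccc(F)c3)ccc21` is the next compound and has not been measured. It differs from compound 2 as follows: carbamoyl in place of methylsulfamoyl on an amine nitrogen. The change keeps the same count of hydrogen-bond donors on the amine nitrogen and removes one acceptor, and the rest of the structure is unchanged. A small weakening is expected, at most modest, and the expected step from compound 2 to compound 3 is a 2.2-fold higher number from compound 2 to compound 3 (0.34 log units; beyond the scatter), which may well fall within the scatter. Compound 3 is expected to give 2.2 nM, with a range from 0.6 nM to 8 nM.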

Compound 3, inhibition constant: 0.2 nM
Estimate against measurement, compound 3: 11-fold (1.04 log units) above; the whole stated range lies above it.
By their numbers in this assay, from the lowest: compound 3; then compound 2; then compound 1.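

In this assay, among these compounds, the group on the amine nitrogen proves to be a live handle on potency: carbamoyl in place of methylsulfamoyl gives a 5.0-fold lower number from compound 2 to compound 3 (0.70 log units; beyond the scatter), the first step that changes one place only. The methylsulfamoyl group, with its sulfur and its second hydrogen-bond acceptor, is therefore not needed for a low number at this position, and the smaller carbamoyl, with 3 heavy atoms against 5, does better on the same core. No measurement on these compounds accounts for the size or the direction of this step.

Going by these compounds, whether the gain rests on the carbonyl or on the unsubstituted terminal nitrogen stays open, and an acetyl group, a methylcarbamoyl group or a methoxycarbonyl group on the same amine nitrogen would separate the two. On these data alone, the step is also known only on the core shared by compound 2 and compound 3, so whether it carries over to the core of compound 1, with its methylsulfonyl group, remains unknown.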